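Enlarging the amide ring: pyrrolidine to phenylpiperidine

The source may hold more compounds than are shown below. What is called first, only, known or untested is meant among the compounds shown, and "the series" means these compounds.

Measured compounds:
compound 1 `CCNC(=O)/C=C/c1c(/C=C/c2ccc(OC)cc2)cc(OC)cc1OC` gives 7060 nM in a functional assay on MCF7 cells (Homo sapiens) for inhibition, read by MTT assay, with a stated time of 48 h; a lower number here means a stronger inhibitor, a higher number a weaker inhibitor
compound 2 `C#CCNC(=O)/C=C/c1c(/C=C/c2ccc(OC)cc2)cc(OC)cc1OC` gives 4560 nM in this assay
compound 3 `COc1ccc(/C=C/c2cc(OC)cc(OC)c2/C=C/C(=O)N2CCCC2)cc1` gives 4200 nM in this assay

The three share one core and differ only at the amide end. Compound 3 carries a pyrrolidin-1-yl group on the carbonyl carbon, and its number is not separated from the other two beyond the scatter: a 1.7-fold lower number from compound 1 to compound 3 (0.23 log units; within the scatter) and a 1.1-fold lower number from compound 2 to compound 3 (0.04 log units; within the scatter) are both small, as is a 1.5-fold lower number from compound 1 to compound 2 (0.19 log units; within the scatter).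

Compound 4 `COc1ccc(/C=C/c2cc(OC)cc(OC)c2/C=C/C(=O)N2CCC(c3ccccc3)CC2)cc1` extends this end further: 4-phenylpiperidin-1-yl in place of pyrrolidin-1-yl on a carbonyl carbon. Among the compounds with values here, no measured step bears directly on this change; the steps from compound 1 and compound 2 to compound 3 show only that swapping small amide groups left the number in this assay essentially unchanged. A step from compound 3 to compound 4 beyond the scatter is therefore not expected, but the added ring is a larger change than any seen so far, so the uncertainty is wider. Compound 4 is estimated at 3500 nM, with a range from 1000 nM to 12000 nM, meaning an expected step of a 1.2-fold lower number from compound 3 to compound 4 (0.08 log units; within the scatter).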

Compound 4, half-maximal inhibitory concentration: 4230 nM
Compound 4: the middle estimate sits 1.2-fold (0.08 log units) below what was measured, and the stated range covers the measured number.
By their numbers in this assay, from the lowest: compounds 3, 4, 2 and 1 (each within the scatter of the next).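

In this assay, 4-phenylpiperidin-1-yl, with 12 heavy atoms and an added aromatic ring, replaces the pyrrolidin-1-yl group of 5 heavy atoms on the carbonyl carbon and gives only a small step (a 1.0-fold higher number from compound 3 to compound 4 (0.00 log units; within the scatter)). The steps from the propargylamino and ethylamino compounds are also small (a 1.1-fold lower number from compound 2 to compound 4 (0.03 log units; within the scatter); a 1.7-fold lower number from compound 1 to compound 4 (0.22 log units; within the scatter)), so all four groups at this position stand within the scatter of one another, even with this much larger group. No measured evidence speaks to why the number stays flat here.

As far as these compounds go, whether any group at this position can move the number beyond the scatter remains open. A carboxylic acid or an amine on the phenyl ring of 4-phenylpiperidin-1-yl would be one way to test this.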